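The compounds below may be only part of what the source reports. "The series", "measured", "known", "first", "only" and "open" are said of these compounds alone.

Working notes on the lactone series.

Compound 1 `O=C1OC[C@H](Cc2ccccc2)[C@H]1Cc1cccc(O)c1` carries a free hydroxy on one aromatic ring. In a functional assay on HL-60 cells (Homo sapiens) for cytotoxicity, read by WST assay, with a stated time of 48 h (a lower number here means that less compound is needed, a higher number that more compound is needed for the effect), compound 1 gives only a limit, > 100000 nM, and no number (the limit of > 100000 nM in this assay, at which 1 of the 3 values shown sits). Compound 2 `COc1cccc(C[C@H]2C(=O)OC[C@@H]2Cc2ccccc2)c1` is the methyl ether of compound 1, the change being (methyl in place of hydrogen on an oxygen on an aromatic ring); in this assay compound 2 gives 66000 nM. The step of an at least 1.5-fold lower number from compound 1 to compound 2 (0.18 log units; that floor lies within the scatter) can only be stated as a floor. Compound 3 `O=C1OC[C@H](Cc2ccccc2O)[C@H]1Cc1ccc(Cl)c(Cl)c1` is built on a different core, carrying a dichlorinated benzyl group and a 2-hydroxyphenyl group; the difference between the two cores is not broken down here. In this assay compound 3 gives 33000 nM, which sits near compound 2.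

Compound 4 `COc1ccccc1C[C@H]1COC(=O)[C@@H]1Cc1ccc(Cl)c(Cl)c1` is not yet measured. It repeats the change seen from compound 1 to compound 2 on the core of compound 3: methyl in place of hydrogen on an oxygen on an aromatic ring. The place is the same in both cases, so this is the same change. Expected is a step of a 1.7-fold lower number from compound 3 to compound 4 (0.22 log units; within the scatter), resting on the floor an at least 1.5-fold lower number from compound 1 to compound 2 (0.18 log units; that floor lies within the scatter). Compound 4 is therefore expected at 20000 nM in this assay. Compound 4 is expected to fall between 6000 nM and 60000 nM.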

Compound 4, half-maximal effective concentration: 14000 nM
Compound 4: middle estimate off by 1.4-fold (0.15 log units), on the high side, and the stated range covers the measured number.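

Working from the shared change, hydroxy to methoxy on the core of compound 3 gives a clear though modest drop in this assay, with a 2.4-fold lower number from compound 3 to compound 4 (0.37 log units; beyond the scatter). Set beside the earlier case, the change goes the same way on both cores, but the earlier step is known only as a floor: the same change on two cores in this assay, an at least 1.5-fold lower number (0.18 log units; that floor lies within the scatter) from compound 1 to compound 2 and a 2.4-fold lower number (0.37 log units; beyond the scatter) from compound 3 to compound 4; the limit leaves it open whether they differ. The two cases therefore support carrying the direction of the change between these two cores, but they do not show that its size carries over, and two cores make no general rule for the series.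

The compounds shown leave open whether a longer chain on the same oxygen, such as ethyl or propyl, would continue the step seen with methyl, or whether an amine or a carboxylic acid in place of the hydroxy would fit the same picture. They also leave open whether the change would go the same way on a third core.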